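The source may report more compounds than this note shows. Statements on the series, on what has been measured and on what is new or still open speak of the compounds shown alone.

Compound 1 `CSc1nc2c([nH]1)C(=O)C=C(Br)C2=O` gives 62.8 uM in a functional assay on MCF7 cells (Homo sapiens) for antiproliferative activity; a higher number here means a weaker inhibitor, a lower number a stronger inhibitor. Compound 2 `COC1=CC(=O)c2[nH]c(SC)nc2C1=O` gives 36 uM in this assay. Compound 3 `O=C1C(Br)=CC(=O)c2[nH]c(-c3ccccn3)nc21` reaches only > 90 uM in this assay, which is a limit of the assay and not a number.

The change from compound 1 to compound 2 is methoxy in place of bromo on a double-bonded ring carbon, and it made a 1.7-fold lower number from compound 1 to compound 2 (0.24 log units; within the scatter). The cores of compound 1 and compound 3 differ by pyridin-2-yl in place of methylsulfanyl on an aromatic carbon, with an at least 1.4-fold higher number from compound 1 to compound 3 (0.15 log units; that floor lies within the scatter). Compound 4 `COC1=CC(=O)c2[nH]c(-c3ccccn3)nc2C1=O` carries the same change as compound 2, (methoxy in place of bromo on a double-bonded ring carbon), on a core that stands at the limit of > 90 uM in this assay, at which 1 of the 3 values shown sits. Among the compounds with values here, for compound 4 the expectation is an at least 1.2-fold lower number from compound 3 to compound 4 (0.10 log units; that floor lies within the scatter), a step of the same size as the one from compound 1 to compound 2, because that step is a 1.7-fold lower number from compound 1 to compound 2 (0.24 log units; within the scatter). Compound 4 is therefore estimated at 70 uM, between 35 uM and 150 uM.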

Compound 4, concentration for 50% inhibition: 26.4 uM
The estimate for compound 4 lay 2.7-fold (0.42 log units) above the measured number; measured number below the stated range.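

In this assay, methoxy in place of bromo gave an at least 3.4-fold lower number from compound 3 to compound 4 (0.53 log units; beyond the scatter), while on the methoxy compounds pyridin-2-yl in place of methylsulfanyl gave a 1.4-fold lower number from compound 2 to compound 4 (0.13 log units; within the scatter). Compound 3 gives > 90 uM, which is a limit of the assay and not a number. The bromo-to-methoxy change therefore gives a step beyond the scatter on the core bearing pyridin-2-yl, but this does not show that it acts differently there than on the core of compound 1: the same change on two cores in this assay, a 1.7-fold lower number (0.24 log units; within the scatter) from compound 1 to compound 2 and an at least 3.4-fold lower number (0.53 log units; beyond the scatter) from compound 3 to compound 4; the limit leaves it open whether they differ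

The compounds shown carry only bromo or methoxy on the double-bonded ring carbon, so the effect of an amine or a longer chain such as ethoxy there remains open. Going by these compounds, it is also open how the change would behave on a core with a carboxylic acid in place of methylsulfanyl.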